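The source may report more compounds than this note shows. Statements on the series, on what has been measured and on what is new or still open speak of the compounds shown alone.

Of the compounds shown here, two built on one shared core have so far been tested in a functional assay on A549 cells (Homo sapiens) for cytotoxicity, read by MTT assay, with a stated time of 72 h; on this read-out higher numbers stand for weaker inhibition and lower numbers for stronger inhibition. There, compound 1 `O=C(N/N=C/c1ccc(F)cc1)Nc1cc2c(Nc3ccc(F)c(Cl)c3)ncnc2cc1O[C@H]1CCOC1` gives 35100 nM and compound 2 `O=C(N/N=C/c1ccc([N+](=O)[O-])cc1)Nc1cc2c(Nc3ccc(F)c(Cl)c3)ncnc2cc1O[C@H]1CCOC1` gives 31200 nM. These two values lie within the scatter of each other, so compound 2 stands level with compound 1 and neither can be ranked above the other. The next compound to be tested is compound 3 `O=C(N/N=C/c1cccc(Cl)c1Cl)Nc1cc2c(Nc3ccc(F)c(Cl)c3)ncnc2cc1O[C@H]1CCOC1`, which keeps the core and differs from compound 2 in one place: 2,3-dichlorophenyl in place of 4-nitrophenyl on a carbon with a double bond to nitrogen. In words, 2,3-dichlorophenyl stands in place of 4-nitrophenyl on a carbon with a double bond to nitrogen. For the measured compounds named here, only one measured step touches this part of the molecule, nitro in place of fluoro on an aromatic carbon, and it gave a 1.1-fold lower number from compound 1 to compound 2 (0.05 log units; within the scatter). Going by the values given here, with that single small step as the only guide, no change beyond the scatter is expected in this assay, although a dichlorinated group has not yet been tried. The expected result is a 1.0-fold lower number from compound 2 to compound 3 (0.02 log units; within the scatter). The estimate for compound 3 is 30000 nM, with an expected range from 14000 nM to 65000 nM.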

Compound 3, half-maximal inhibitory concentration: 25000 nM
The estimate for compound 3 lay 1.2-fold (0.08 log units) above the measured number; low and high end bracket the measured number.
By their numbers in this assay, from the lowest: compounds 3, 2 and 1 (each within the scatter of the next).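

In this assay, putting 2,3-dichlorophenyl in place of 4-nitrophenyl on the carbon with a double bond to nitrogen gives a 1.2-fold lower number from compound 2 to compound 3 (0.10 log units; within the scatter), and putting it in place of 4-fluorophenyl gives a 1.4-fold lower number from compound 1 to compound 3 (0.15 log units; within the scatter). For the compounds shown here, the earlier pair compared only two groups each with one substituent on the ring, whereas this group carries two chlorine atoms and has no hydrogen-bond acceptors, against two for 4-nitrophenyl, and still the values stay level, so the three compounds cannot be ranked in this read-out. No measurement is available that could explain why these groups give such similar numbers.

On these data alone, all three compounds carry a substituted phenyl ring at this position, so it remains open whether an amine, a carboxylic acid or a longer alkyl chain there would move the number beyond the scatter. The shared core is also the same throughout, so these compounds cannot tell whether a change elsewhere on it would matter more than the changes on this ring.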